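Fluorine Placement and Inhibition on T47D Cells

The source may hold more compounds than are shown below. What is called first, only, known or untested is meant among the compounds shown, and "the series" means these compounds.

Of the compounds shown here, two have been tested in a functional assay on T47D cells (Homo sapiens) for inhibition; on this read-out lower numbers stand for stronger inhibition and higher numbers for weaker inhibition. Compound 1, `Oc1cccc(-c2cc(-c3ccc(F)cc3)cc(-c3ccccc3O)n2)c1`, gives only a limit of > 50000 nM, so no number is known for it. For the measured compounds named here, compound 2, `Oc1ccc(-c2cc(-c3ccccc3F)cc(-c3cccc(O)c3)n2)cc1`, gives 6370 nM in this assay and is thus the only compound with a measured number. The remaining result is a limit, (the limit of > 50000 nM in this assay, at which 1 of the 2 values shown sits). Compound 3, `Oc1ccc(-c2cc(-c3ccc(F)cc3)cc(-c3cccc(O)c3)n2)cc1`, has not yet been measured. It differs from compound 2 in one place: 4-fluorophenyl in place of 2-fluorophenyl on an aromatic carbon opposite the ring nitrogen. Going by the values given here, no measured step links two compounds that differ in a single place, so nothing sets the size of this change. Compound 1 also carries 4-fluorophenyl yet differs from compound 3 in a second place too, so it is no clean guide. The step from compound 2 to compound 3 is expected to be small, within the scatter or slightly toward weaker inhibition, a 1.3-fold higher number from compound 2 to compound 3 (0.10 log units; within the scatter). Compound 3 is therefore estimated at 8000 nM, with a range from 2500 nM to 30000 nM.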

Compound 3, half-maximal inhibitory concentration: 5000 nM
Compound 3: middle estimate off by 1.6-fold (0.20 log units), on the high side; measured number inside the range.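

On the aromatic carbon opposite the ring nitrogen, 4-fluorophenyl in place of 2-fluorophenyl now has a measured size in this assay: the swap gives a 1.3-fold lower number from compound 2 to compound 3 (0.11 log units; within the scatter), so the place of the fluorine on this ring does not move the read-out beyond the scatter. The step beyond the scatter belongs to the other change, 4-hydroxyphenyl in place of 2-hydroxyphenyl, which gives an at least 10-fold lower number from compound 1 to compound 3 (1.00 log units; beyond the scatter). Compound 1 stands at a limit, not a number: the limit of > 50000 nM in this assay, at which 1 of the 3 values shown sits.

The compounds shown leave open whether 3-fluorophenyl, or a ring carrying an amine or a carboxylic acid, would stay as close to compound 3 at this carbon. They also leave open whether a longer chain in place of the fluorophenyl ring would be tolerated in this assay.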